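Chloro to trifluoromethyl exchange on the shared core

The source may report more compounds than this note shows. Statements on the series, on what has been measured and on what is new or still open speak of the compounds shown alone.

Measured in an ADME assay on microsomes from liver (Homo sapiens) for metabolic stability, with a stated time of 30 min; on this read-out lower numbers stand for a less stable compound and higher numbers for a more stable compound:
compound 1 `CC(=O)N[C@@H](C)/C=C/c1ccc(Oc2ccc3nc(C)sc3c2Cl)nc1`: 87%
compound 2 `CC(=O)N[C@@H](C)/C=C/c1ccc(Oc2ccc3nc(C(C)C)sc3c2Cl)nc1`: 83%
compound 3 `CC(=O)N[C@@H](C)/C=C/c1ccc(Oc2ccc3nc(C(C)(C)O)sc3c2Cl)nc1`: 92%

Compound 2 stands within the scatter of both compound 1 and compound 3, with a number 4 percentage points lower from compound 1 to compound 2 (within the scatter) and a number 9 percentage points higher from compound 2 to compound 3 (within the scatter). Compound 4 `CC(=O)N[C@@H](C)/C=C/c1ccc(Oc2ccc3nc(C(C)C)sc3c2C(F)(F)F)nc1` follows from compound 2 through (trifluoromethyl in place of chloro on an aromatic carbon), that is, trifluoromethyl in place of chloro on an aromatic carbon. Within the data shown here, no measured step alters the chloro group. The three steps available all exchange another group, and a number 5 percentage points higher from compound 1 to compound 3 (within the scatter) likewise stays within the scatter. They test this exchange only indirectly, so no step beyond the scatter is expected. The expected step is a number 1 percentage points lower from compound 2 to compound 4 (within the scatter). For compound 4 the estimated value is 82%, with an expected range from 68% to 94%.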

Compound 4, percent of the compound remaining: 87%
For compound 4 the middle estimate is 5 percentage points below the measured one, and the stated range covers the measured number.
By their numbers in this assay, from the lowest: compounds 2, 1, 4 and 3 (each within the scatter of the next).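

In this assay, the exchange on an aromatic carbon ortho to a fused ring gives a number 4 percentage points higher from compound 2 to compound 4 (within the scatter), so chloro, with 1 heavy atom, and trifluoromethyl, with 4, cannot be told apart on this read-out. Among these compounds, this is the first measured step at this position, as the earlier steps all lie at the other substituent, and it rests on the isopropyl pair alone. Nothing available gives a reason for this step.

Open, going by these compounds, is whether the same exchange behaves alike with methyl or 1-hydroxy-1-methylethyl on the shared core. Also open, on these data alone, is whether a nitrile or a methoxy group at this position stays within the scatter of chloro and trifluoromethyl.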